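The source may hold more compounds than are shown below. What is called first, only, known or untested is meant among the compounds shown, and "the series" means these compounds.

In an ADME assay on cells (Hepatocyte, Rattus norvegicus) for pharmacokinetics, read by LC-MS, with a stated time of 90 min, tested at 1 uM (on this read-out higher numbers stand for fast clearance and lower numbers for slow clearance), compound 3 `CC(C)OC(=O)Nc1c(N)nc(-c2nn(Cc3ccccc3F)c3ncccc23)nc1N` gives 15 mL/min/kg, the second highest of three numbers. Compound 1 `COC(=O)N(Cc1ccc(F)cc1)c1c(N)nc(-c2nn(Cc3ccccc3F)c3ncccc23)nc1N` gives 40 mL/min/kg and compound 2 `COC(=O)Nc1c(N)nc(-c2nn(Cc3ccccc3F)c3ncccc23)nc1N` gives 1.67 mL/min/kg. Compound 4 `Nc1nc(-c2nn(Cc3ccccc3F)c3ncccc23)nc(N)c1N1C[C@@H](C(F)(F)F)OC1=O` differs from compound 3 as follows: 2-oxo-5-(trifluoromethyl)-1,3-oxazolidin-3-yl in place of (isopropoxycarbonyl)amino on an aromatic carbon. Among the compounds with values here, two measured steps bear on this change. Hydrogen in place of 4-fluorobenzyl on an amide-type nitrogen gave a large step, a 24-fold lower number from compound 1 to compound 2 (1.38 log units; beyond the scatter). Isopropyl in place of methyl on an oxygen gave a modest one, a 9.0-fold higher number from compound 2 to compound 3 (0.95 log units; beyond the scatter). Like compound 1 at 40 mL/min/kg, compound 4 has no hydrogen on that nitrogen, which hints at a higher number. Neither step tests a ring there, however. The expected step is therefore a 1.3-fold lower number from compound 3 to compound 4 (0.10 log units; within the scatter), with nothing expected beyond the scatter in this assay. For compound 4 the estimated clearance is 12 mL/min/kg, with an expected range from 4 mL/min/kg to 35 mL/min/kg.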

Compound 4, clearance: 26.7 mL/min/kg
Compound 4: middle estimate off by 2.2-fold (0.35 log units), on the low side; low and high end bracket the measured number.
By their numbers in this assay, from the lowest: compound 2; then compounds 3, 4 and 1 (each within the scatter of the next, the first and the last beyond it).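

In this assay, the ring 2-oxo-5-(trifluoromethyl)-1,3-oxazolidin-3-yl in place of (isopropoxycarbonyl)amino on this aromatic carbon gives a step within the scatter (a 1.8-fold higher number from compound 3 to compound 4 (0.25 log units; within the scatter)), so losing the hydrogen on that nitrogen and closing a ring leave these two compounds indistinguishable. The same ring in place of (methoxycarbonyl)amino gives a large step (a 16-fold higher number from compound 2 to compound 4 (1.20 log units; beyond the scatter)), which keeps compound 2 apart from both. Nothing measured here explains these numbers.

Still open is whether the trifluoromethyl or the ring itself sets the number, as no compound shown carries the ring without trifluoromethyl. A simple amine or a longer chain at this position also remains untested among these compounds.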